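Swapping phenyl for methyl on the ring nitrogen

The source may hold more compounds than are shown below. What is called first, only, known or untested is meant among the compounds shown, and "the series" means these compounds.

In an ADME assay on Vero cells (Chlorocebus sabaeus) for antiproliferative activity, read by MTT assay (on this read-out lower numbers stand for stronger inhibition and higher numbers for weaker inhibition), compound 1 `Fc1ccc(N2CCN(c3nc(-n4ccc5ccccc54)c4ccccc4n3)CC2)cc1` gives 50 ug/mL and compound 2 `c1ccc(N2CCN(c3nc(-n4ccc5ccccc54)c4ccccc4n3)CC2)cc1` gives 50 ug/mL, so compound 2 stands level with compound 1. For the measured compounds named here, the one measured step, no change at the digits printed from compound 1 to compound 2 (within the scatter), is hydrogen in place of fluoro on an aromatic carbon; it is the only guide, though it leaves the phenyl in place. Compound 3 `CN1CCN(c2nc(-n3ccc4ccccc43)c3ccccc3n2)CC1` differs from compound 2 by methyl in place of phenyl on an amine nitrogen in a ring. With no measured evidence for a shift in either direction, the expected change in this assay is none beyond the scatter, an expected no change at the digits printed from compound 2 to compound 3 (within the scatter). Compound 3 is estimated at 50 ug/mL, within an expected range of 25 ug/mL to 100 ug/mL.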

Compound 3, half-maximal inhibitory concentration: 22.3 ug/mL
Beside the measured number, compound 3's estimate is 2.2-fold (0.35 log units) above it; measured number below the stated range.
By their numbers in this assay, from the lowest: compound 3; then compounds 1 and 2 (each within the scatter of the next).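

In this assay the group on this amine nitrogen does register: methyl in place of phenyl brings a 2.2-fold lower number from compound 2 to compound 3 (0.35 log units; beyond the scatter) and methyl in place of 4-fluorophenyl brings a 2.2-fold lower number from compound 1 to compound 3 (0.35 log units; beyond the scatter) even though removing the fluoro from the phenyl had shown no change. Replacing the whole phenyl thus moves the number where editing it did not. No measured evidence here bears on why the number moves. As far as these compounds go, whether a hydrogen, an ethyl or a benzyl on this nitrogen would go further in the same direction remains open. So does whether a longer chain would reverse the step.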